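Mirror-image pair on the shared core

The compounds below may be only part of what the source reports. "The series", "measured", "known", "first", "only" and "open" are said of these compounds alone.

Measured so far:
compound 1 `O=C(NCc1cc(C(F)(F)F)cc(C(F)(F)F)c1)[C@]1(c2ccccc2)CC[C@@H](N2CCC(c3ccc(F)cc3)CC2)CC1` gives 150 nM in an assay on isolated protein for displacement of a labelled ligand from Substance-P receptor (Homo sapiens); on this read-out higher numbers stand for weaker inhibition and lower numbers for stronger inhibition;
compound 2 `Fc1ccc(C2CCN([C@H]3CC[C@](CNCc4cc(C(F)(F)F)cc(C(F)(F)F)c4)(c4ccccc4)CC3)CC2)cc1` gives 1.7 nM in this assay.

Within the data shown here, on these two numbers compound 2 stands lowest; the only other value, that of compound 1, lies higher by a gap well beyond the scatter, and the two compounds differ in more than one place, so that gap is noted without further reading.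

Compound 3 `Fc1ccc(C2CCN([C@H]3CC[C@@](CNCc4cc(C(F)(F)F)cc(C(F)(F)F)c4)(c4ccccc4)CC3)CC2)cc1` is the unmeasured partner of compound 2. The change is the two compounds have the same atoms and bonds and differ only in configuration as drawn: 2 of 2 stereo elements differ (all stereocentres are inverted: mirror images); a stereocentre at a saturated ring carbon is drawn s in compound 2 and r in compound 3; a stereocentre at a saturated ring carbon is drawn s in compound 2 and r in compound 3; in words, the two compounds have the same atoms and bonds and differ only in configuration as drawn, all stereocentres inverted, mirror images.

No measured pair on this core shows what inversion of both stereocentres does, so the size of the step rests on no shown number. The expectation is a step from compound 2 to compound 3 of a 35-fold higher number from compound 2 to compound 3 (1.55 log units; beyond the scatter) toward a higher value, with wide uncertainty. Compound 3 is therefore estimated at 60 nM in this assay, within 4 nM to 900 nM.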

Compound 3, half-maximal inhibitory concentration: 82 nM
For compound 3 the middle estimate is 1.4-fold (0.14 log units) below the measured one; the range from low to high includes it.
By their numbers in this assay, from the lowest: compound 2; then compounds 3 and 1 (each within the scatter of the next).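

Inversion of both stereocentres alone produces a 48-fold higher number from compound 2 to compound 3 (1.68 log units; beyond the scatter) in this assay, the first step on the shared core that can be read at a single place. With nothing leaving and nothing entering, this large step, beyond the scatter, can be set on configuration alone: the fact that compounds 2 and 3 differ only in the configuration as drawn. The configuration drawn in compound 2 is therefore the preferred one of this pair, and the two saturated ring carbons are a position where the arrangement as drawn matters in this assay.

Going by these compounds, the share of each stereocentre in the step stays open, as both change together in this pair. Also open, on these data alone, is whether the same preference holds in compound 1, or when methoxy groups stand in place of the two trifluoromethyl groups.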